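Shortening the acyl chain on the core of compound 1

The source may hold more compounds than are shown below. What is called first, only, known or untested is meant among the compounds shown, and "the series" means these compounds.

Measured so far:
- compound 1 `CCCCCCCCC(=O)N1c2ccccc2CCC1C(=O)Nc1ccccc1C(F)(F)F` gives 4320 nM in a functional assay on PC-3 cells (Homo sapiens) for cytotoxicity, read by sulforhodamine B assay, with a stated time of 72 h; on this read-out lower numbers stand for stronger inhibition of growth and higher numbers for weaker inhibition of growth
- compound 3 `CCCCCCCCC(=O)N1c2ccccc2CCC1C(=O)Nc1ccccc1O` gives 45200 nM
- compound 2 `O=C(Nc1ccc(O)cc1)C1CCc2ccccc2N1` gives > 100000 nM; this is a limit of the assay, not a number

Among the two numbers given, compound 1 stands lowest; the nearest is compound 3, and the change a 10-fold higher number from compound 1 to compound 3 (1.02 log units; beyond the scatter) is large. For compound 2 the assay reports only a limit, (the limit of > 100000 nM in this assay, at which 1 of the 3 values shown sits).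

Compound 4 `CC(=O)N1c2ccccc2CCC1C(=O)Nc1ccccc1C(F)(F)F` is the next step from compound 1. The difference is hydrogen in place of heptyl on a saturated chain carbon bound to a carbonyl carbon. Going by the values given here, no measured step touches this part of the molecule: the only measured step, a 10-fold higher number from compound 1 to compound 3 (1.02 log units; beyond the scatter), changes a group on an aromatic carbon elsewhere and gives no direct guide. Compound 2 differs from compound 1 in two places, lacking the acyl group altogether and carrying a different group on the aromatic ring, and its value shows only a limit.

Compound 4 is therefore expected to sit at a weaker, higher number, the estimated step being a 6.9-fold higher number from compound 1 to compound 4 (0.84 log units; beyond the scatter). The estimate for compound 4 is 30000 nM, with a range from 8000 nM to 100000 nM.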

Compound 4, concentration for 50% growth inhibition: > 80000 nM
Compound 4: only a limit was reported; the forecaster's own chance of this, stated with the estimate: 25%; at least 2.6-fold (0.42 log units) between middle value and limit.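

Compound 4 gives > 80000 nM in this assay and this is a limit of the assay, not a number. Going by these compounds alone, replacing heptyl with hydrogen is the first measured change at this place on the core of compound 1, and it gives an at least 18-fold higher number from compound 1 to compound 4 (1.26 log units; beyond the scatter) as a large loss of growth inhibition. The earlier step lay on the aromatic ring, so this shows that the acyl chain also matters for this read-out, leaving octylcarbonyl far ahead of acetyl here.

As far as these compounds go, only these two acyl groups are compared, so it remains open how growth inhibition changes with chain length in between, for example with a butyl chain, or with a longer chain such as decyl. It is also unknown whether a chain ending in an amine or a carboxylic acid would keep the activity of compound 1.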